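A few compounds are considered here, and "the series" means these few. Any claim that something is new, unique, unknown or untested is made for them only; others in the source may bear on it.

Measured so far:
compound 1 `CC(O)CSc1nc(NCc2ccc(-c3ccccn3)cc2)c2[nH]nc(C(C)C)c2n1` — 62 nM
compound 2 `CC(C)c1n[nH]c2c(NCc3ccc(-c4ccccn4)cc3)nc(SCC(C)(C)O)nc12` — 507 nM
compound 3 `CC(C)c1n[nH]c2c(NCc3ccc(-c4ccccn4)cc3)nc(SCCN)nc12` — 22 nM

In a functional assay on HT cells (Homo sapiens) for antiproliferative activity, read by fluorescence, with a stated time of 72 h (a lower number here means a stronger inhibitor of growth, a higher number a weaker inhibitor of growth), compound 3 gives 22 nM, the lowest of the three numbers; its steps to both other compounds are beyond the scatter, so on these numbers it is the strongest growth inhibitor of the set. The nearest to it is compound 1 with 62 nM, and the furthest is compound 2 with 507 nM.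

Compound 4 `CNCCSc1nc(NCc2ccc(-c3ccccn3)cc2)c2[nH]nc(C(C)C)c2n1` has not yet been measured in this assay. It differs from compound 3 in one place: methyl in place of hydrogen on an amine nitrogen

Among the measured compounds shown here, none of the measured steps changes an amine nitrogen, so no step bears directly on this change. For the measured compounds named here, the one step that adds a methyl, an 8.2-fold higher number from compound 1 to compound 2 (0.91 log units; beyond the scatter), places it on a saturated chain carbon bound to an oxygen, a different setting, and it gives a modest weakening. The other steps, a 2.8-fold lower number from compound 1 to compound 3 (0.45 log units; beyond the scatter) and a 23-fold lower number from compound 2 to compound 3 (1.36 log units; beyond the scatter), exchange the whole end group of the chain and say nothing about a methyl on nitrogen.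

With only an indirect parallel, the step for compound 4 is expected to be small, at most a mild weakening: a 1.6-fold higher number from compound 3 to compound 4 (0.20 log units; within the scatter). Compound 4 is therefore estimated to give 35 nM in this assay, within a range of 12 nM to 100 nM.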

Compound 4, concentration for 50% growth inhibition: 56 nM
For compound 4 the middle estimate is 1.6-fold (0.20 log units) below the measured one; low and high end bracket the measured number.
By their numbers in this assay, from the lowest: compound 3; then compounds 4 and 1 (each within the scatter of the next); then compound 2.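

In this assay, a methyl on the amine nitrogen of the 2-aminoethyl chain is not neutral: the change gives a 2.5-fold higher number from compound 3 to compound 4 (0.41 log units; beyond the scatter), so the unsubstituted amino end of compound 3 remains the lowest number in the set. Together with the earlier step on the chain carbon (an 8.2-fold higher number from compound 1 to compound 2 (0.91 log units; beyond the scatter)), this makes a second place on the chain where an added methyl raises the number, and none of the compounds shown goes against this, although these two steps sit in different chains and settings. The methylated amine still holds much of the activity, with a 9.1-fold lower number from compound 2 to compound 4 (0.96 log units; beyond the scatter), while the 2-(methylamino)ethyl chain cannot be told apart from the hydroxyl-bearing chain of compound 1 (a 1.1-fold lower number from compound 1 to compound 4 (0.04 log units; within the scatter)).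

The compounds shown leave open whether a 2-(dimethylamino)ethyl chain, an ethyl group on the nitrogen or an acetyl amide there would continue this direction. They also leave open how a longer chain carrying the same amine would behave, and whether the step seen here holds on other cores or in other cells. Nothing available here explains why the methyl on the nitrogen changes the number.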